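The compounds below may be only part of what the source reports. "The series", "measured", "known", "first", "only" and "open" are said of these compounds alone.

Measured so far in an assay on HeLa cells for inhibition of Indoleamine 2,3-dioxygenase 1 (Homo sapiens), read by spectrophotometry, with a stated time of 24 h; a lower number here means that less compound is needed, a higher number that more compound is needed for the effect:
Compound 1 `CC(=O)Nc1ccc(S(=O)(=O)NNc2ccc(C)cc2)cc1` gives 1170 nM in this assay.
Compound 2 `CC(=O)Nc1ccc(S(=O)(=O)NNc2ccc(Br)cc2)cc1` gives 85 nM in this assay.
Compound 3 `CC(=O)Nc1ccc(S(=O)(=O)NNc2cccc(Br)c2)cc1` gives 7560 nM in this assay.

Compound 2 stands at the lowest of the three numbers, and both of its neighbours lie beyond the scatter: a 14-fold lower number from compound 1 to compound 2 (1.14 log units; beyond the scatter), and an 89-fold higher number from compound 2 to compound 3 (1.95 log units; beyond the scatter). Compound 4 `CC(=O)Nc1ccc(S(=O)(=O)NNc2ccc(Br)c(C)c2)cc1` is built from compound 2 by a single change: methyl in place of hydrogen on an aromatic carbon. Among the compounds with values here, no measured step adds a group to the ring of compound 2 while the bromo stays in place, so the step to compound 4 has no direct precedent. Within the data shown here, the steps that bear on it are indirect. The change from compound 1 to compound 2 shows that the exchange of methyl for bromo on this ring is large in this assay; the change from compound 2 to compound 3 shows that the same bromo at a different carbon gives a large rise; and a 6.5-fold higher number from compound 1 to compound 3 (0.81 log units; beyond the scatter) is modest. Among the measured compounds shown here, because compound 4 keeps the bromo of compound 2 and 85 nM is the best number seen, a large loss is not expected, but a methyl entering at a place no measured compound occupies leaves room for a modest rise. Compound 4 is therefore estimated at 200 nM, within 50 nM to 900 nM, a step of a 2.4-fold higher number from compound 2 to compound 4 (0.37 log units; beyond the scatter) that is expected rather than known.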

Compound 4, half-maximal effective concentration: 130 nM
For compound 4 the middle estimate is 1.5-fold (0.19 log units) above the measured one, and the stated range covers the measured number.
By their numbers in this assay, from the lowest: compounds 2 and 4 (each within the scatter of the next); then compound 1; then compound 3.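

In this assay, within the data shown here, the earlier steps exchanged the para-free ring's groups or moved the bromo, whereas here the bromo stays in place and a methyl enters ortho to a bromo group and meta to a large group: a 1.5-fold higher number from compound 2 to compound 4 (0.18 log units; within the scatter). A methyl at this carbon therefore leaves the number within the scatter of compound 2, a sharp contrast with the shift of the bromo itself, an 89-fold higher number from compound 2 to compound 3 (1.95 log units; beyond the scatter). No measurement bears on why this added methyl is tolerated.

The compounds shown leave open whether this carbon would accept anything larger or different from a methyl, such as an ethyl chain, a methoxy group or an amine, since a single small group says little about how much room the position allows. They also leave open whether the same methyl would give the same result with a chloro group in place of the bromo, so the tolerance seen here belongs only to the pair of compound 2 and compound 4.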